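Benzylamine series: piperidinyl to aminophenyl at the chain carbon

The compounds below may be only part of what the source reports. "The series", "measured", "known", "first", "only" and "open" are said of these compounds alone.

Compound 1, `O=C(O)CNc1cccc(CNc2cc(C(F)(F)F)cc3[nH]ncc23)c1`: in an assay for inhibition of Indoleamine 2,3-dioxygenase 1 (Homo sapiens), with stated times of 10 min and 60 min (on this read-out lower numbers stand for stronger inhibition and higher numbers for weaker inhibition), compound 1 gives > 100000 nM, which is a limit of the assay.
Compound 2, `OC1CCCC(Nc2cccc(CNc3cc(C(F)(F)F)cc4[nH]ncc34)c2)C1`: compound 2 gives > 100000 nM, again a limit of the assay.
Compound 3, `FC(F)(F)c1cc(NC[C@@H]2CCCCN2)c2cn[nH]c2c1`: compound 3 gives 18700 nM.

Going by the values given here, compound 3 carries the only number in this assay; the other two values are limits, as the limit of > 100000 nM in this assay, at which 2 of the 3 values shown sit, records. Among the compounds with values here, the single step between measured compounds, a step that the two limits leave unreadable from compound 1 to compound 2, runs between two limits and gives no readable size.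

Compound 4, `Nc1cccc(CNc2cc(C(F)(F)F)cc3[nH]ncc23)c1`, differs from compound 3 by 3-aminophenyl in place of piperidin-2-yl on a saturated chain carbon bound to a nitrogen on an aromatic ring. Within the data shown here, no measured step covers this change. What is known: compounds 1 and 2, which bear carboxymethyl or 3-hydroxycyclohexyl on a nitrogen on an aromatic ring of the shared core, both sit at the limit, whereas compound 3 gives a number. Compound 4 is therefore expected to fall toward the weaker side, with an estimated step of a 4.3-fold higher number from compound 3 to compound 4 (0.63 log units; beyond the scatter). For compound 4 the expected value in this assay is 80000 nM, estimated between 20000 nM and 300000 nM, with a fair chance that only a limit is returned.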

Compound 4, half-maximal inhibitory concentration: > 100000 nM
Compound 4 ended at the assay's limit (the forecaster's own chance of this, stated with the estimate: 50%); at least 1.2-fold (0.09 log units) between middle value and limit.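

Setting 3-aminophenyl in place of piperidin-2-yl on a saturated chain carbon bound to a nitrogen on an aromatic ring gives the first readable step in this assay at this position: an at least 5.3-fold higher number from compound 3 to compound 4 (0.72 log units; beyond the scatter). Compound 4 carries hydrogen in place of carboxymethyl or 3-hydroxycyclohexyl on a nitrogen on an aromatic ring and still ends at a limit of the assay, so the limits of compound 1 and compound 2 do not depend on those two groups alone. The steps among compound 1, compound 2 and compound 4 cannot be read: the limit of > 100000 nM in this assay, at which 3 of the 4 values shown sit.

Going by these compounds, how far compound 4 lies past its limit stays open. Also open, on these data alone, is whether plain phenyl, cyclohexyl or an open-chain amine on the same chain carbon would return a number, as compound 3 does.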